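The compounds below may be only part of what the source reports. "The series", "measured", "known", "first", "only" and "open" are said of these compounds alone.

Measured so far in a functional assay on aorta (Rattus norvegicus, strain Wistar) for inhibition; a higher number here means that more compound is needed for the effect, a lower number that less compound is needed:
compound 1, `Cn1c(=O)c2ccccc2c(=O)n1CCCNC(=O)OC(C)(C)C`: 23600 nM
compound 2, `Cn1c(=O)c2c(Cl)cccc2c(=O)n1CCCNC(=O)OC(C)(C)C`: 4850 nM
compound 3, `Cn1c(=O)c2ccccc2c(=O)n1CCN=[N+]=[N-]`: 15900 nM

Compound 2 differs from compound 1 by chloro in place of hydrogen on an aromatic carbon and gives a 4.9-fold lower number from compound 1 to compound 2 (0.69 log units; beyond the scatter) in this assay. Compound 3 and compound 1 carry different cores; the difference between the two cores is not broken down here. The values of compound 3 and compound 1 lie within the scatter of each other, while the value of compound 2 lies beyond the scatter below that of compound 3.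

Compound 4, `Cn1c(=O)c2c(Cl)cccc2c(=O)n1CCN=[N+]=[N-]`, is not yet measured. It differs from compound 3 by chloro in place of hydrogen on an aromatic carbon, the same change as from compound 1 to compound 2; the place is described in the same words in both cases.

For compound 4 a step of a 4.0-fold lower number from compound 3 to compound 4 (0.60 log units; beyond the scatter) is expected in this assay. This expectation rests on the step of a 4.9-fold lower number from compound 1 to compound 2 (0.69 log units; beyond the scatter) and on the value of compound 3, 15900 nM, and it is tempered because the step of a 4.9-fold lower number from compound 1 to compound 2 (0.69 log units; beyond the scatter) stands alone. Compound 4 is thus estimated at 4000 nM, with a range from 1500 nM to 11000 nM.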

Compound 4, half-maximal effective concentration: 13100 nM
The estimate for compound 4 lay 3.3-fold (0.52 log units) below the measured number; the whole stated range lies below it.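

In this assay, chloro in place of hydrogen on an aromatic carbon gives a 1.2-fold lower number from compound 3 to compound 4 (0.08 log units; within the scatter), and this step does not match the one seen on the core of compound 1: the same change on two cores in this assay, a 4.9-fold lower number (0.69 log units; beyond the scatter) from compound 1 to compound 2 and a 1.2-fold lower number (0.08 log units; within the scatter) from compound 3 to compound 4, 4.0-fold (0.60 log units) apart, beyond the scatter of two such steps. The change therefore cannot be carried from the core of compound 1 to the core of compound 3 with its size kept. Within the data shown here, two pairs show only that the step depends on the core; they do not show which part of the core matters, or how the change would behave on a third core.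

From the compounds shown here alone, it remains open whether the azide or the chain length separates the two steps. Also open, going by these compounds, is whether an amine in place of the azide, or bromo in place of chloro, would follow compound 2 or compound 4.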